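Swapping the carboxy of compound 2 for pyridin-3-yl

The compounds below may be only part of what the source reports. "The series", "measured", "known", "first", "only" and "open" are said of these compounds alone.

In a physicochemical assay for solubility, at pH 6.8 (on this read-out higher numbers stand for higher solubility and lower numbers for lower solubility), compound 1 `Cc1c(COc2cccc(OCC3CCOCC3)c2)[nH]c2ccc(Cl)cc2c1=O` gives < 1000 nM, which is a limit and not a number. As far as these compounds go, compound 2 `Cc1c(COc2cccc(OCC3CCOCC3)c2)[nH]c2ccc(C(=O)O)cc2c1=O` gives >= 100000 nM, which is also a limit, so its exact place is unknown.

Compound 3 `Cc1c(COc2cccc(OCC3CCOCC3)c2)[nH]c2ccc(-c3cccnc3)cc2c1=O` changes one group of compound 2: pyridin-3-yl in place of carboxy on an aromatic carbon. Going by the values given here, only one measured step bears on this change, the large rise an at least 100-fold higher number from compound 1 to compound 2 (2.00 log units; beyond the scatter), where carboxy replaced chloro. With carboxy gone again, a large fall is expected in this assay, and the estimated step is an at least 140-fold lower number from compound 2 to compound 3 (2.15 log units; beyond the scatter). For compound 3 the estimate is 700 nM, with an expected range from 100 nM to 5000 nM.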

Compound 3, solubility: < 1000 nM
Compound 3: only a limit was reported; the forecaster's own chance of this, stated with the estimate: 55%; the middle value does not contradict the limit.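

In this assay, putting pyridin-3-yl in place of carboxy on this aromatic carbon brings an at least 100-fold lower number from compound 2 to compound 3 (2.00 log units; beyond the scatter). The high reading of compound 2 is therefore not kept with this ring in the same place, and compound 3 shares its limit with compound 1: the limit of < 1000 nM in this assay, at which 2 of the 3 values shown sit. The step between compound 1 and compound 3 cannot be read, as both values are limits.

As far as these compounds go, how far under that limit either compound lies stays open. Also open, from the compounds shown here alone, is whether an amine or a longer chain ending in a carboxylic acid would keep the reading high here.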